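A few compounds are considered here, and "the series" means these few. Any claim that something is new, unique, unknown or untested is made for them only; others in the source may bear on it.

Compound 1 `COc1ccc(C(=O)NNC(=S)Nc2csc(-c3ccc(C)cc3)c2)cc1` and compound 2 `Cc1ccc(-c2cc(NC(=S)NNC(=O)c3ccc(O)cc3)cs2)cc1` share one core. In a functional assay on Hs 683 cells (Homo sapiens) for inhibition, read by colorimetric assay and MTT assay, with a stated time of 72 h (a lower number here means a stronger inhibitor, a higher number a weaker inhibitor), compound 1 gives 12000 nM, while compound 2 gives 49000 nM. The only difference between them is hydrogen in place of methyl on an oxygen on an aromatic ring, and that change made a 4.1-fold higher number from compound 1 to compound 2 (0.61 log units; beyond the scatter). Compound 3 `COc1ccc(-c2nnc(Nc3csc(-c4ccccc4)c3)s2)cc1` is built on a second core; the difference between the two cores is not broken down here. In this assay compound 3 gives 5000 nM, the lowest of the three numbers recorded so far. Compound 4 `Oc1ccc(-c2nnc(Nc3csc(-c4ccccc4)c3)s2)cc1` carries the same change on this second core, (hydrogen in place of methyl on an oxygen on an aromatic ring); the position is described in identical words for both pairs, so it is the same change, now on a different core. Going by the values given here, only one precedent exists for it. On that basis the step from compound 3 to compound 4 is expected to be a 4.0-fold higher number from compound 3 to compound 4 (0.60 log units; beyond the scatter), an estimate that rests on the earlier step of a 4.1-fold higher number from compound 1 to compound 2 (0.61 log units; beyond the scatter). With that step applied to compound 3, compound 4 is expected to give about 20000 nM, estimated to lie between 8000 nM and 50000 nM.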

Compound 4, half-maximal inhibitory concentration: 26000 nM
Beside the measured number, compound 4's estimate is 1.3-fold (0.11 log units) below it, and the stated range covers the measured number.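

Going from methoxy to hydroxy on the second core gave a 5.2-fold higher number from compound 3 to compound 4 (0.72 log units; beyond the scatter) in this assay, and this step matches the one on the first core: the same change on two cores in this assay, a 4.1-fold higher number (0.61 log units; beyond the scatter) from compound 1 to compound 2 and a 5.2-fold higher number (0.72 log units; beyond the scatter) from compound 3 to compound 4, 1.3-fold (0.10 log units) apart, within the scatter of two such steps

Within these two cores, the change therefore carries over, with the number rising on both and by a similar size. Going by these compounds alone, this rests on only two pairs in a single cell assay, so it does not show that the step would hold on any further core, and it gives no reason why the 4-hydroxyphenyl compounds give the higher numbers.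

The compounds shown leave open what a longer chain on this oxygen, such as ethoxy, or an amine in place of the hydroxy would do to the number in this assay. Also open is how much the two cores themselves contribute, as no pair shown differs in the core alone.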